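A few compounds are considered here, and "the series" means these few. Any claim that something is new, unique, unknown or untested is made for them only; others in the source may bear on it.

Compound 1, `Nc1cc(N)c2nc(-c3ccccc3)c(Oc3ccc(Cl)c(Cl)c3)nc2c1`: in a functional assay on COLO 205 cells (Homo sapiens) for inhibition, read by sulforhodamine B assay, with a stated time of 48 h (on this read-out lower numbers stand for higher toxicity in this test and higher numbers for lower toxicity in this test), compound 1 gives < 100000 nM, which is a limit of the assay.
Compound 2, `COc1ccc(CNc2nc3cc(N)cc(N)c3nc2-c2ccccc2)cc1OC`: in this assay compound 2 gives < 100000 nM, again a limit.
Compound 3, `COc1cc(CNc2nc3cc(N)cc(N)c3nc2-c2ccccc2)cc(OC)c1OC`: in this assay compound 3 gives < 50200 nM, also a limit.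

Compound 2 therefore stands nowhere definite on the numbers shown: its result is a limit, and the two other results are limits as well. Two of the three values sit at the limit of < 100000 nM in this assay, at which 2 of the 3 values shown sit, and one at the limit of < 50200 nM in this assay, at which 1 of the 3 values shown sits. Going by the values given here, the single measured step, a step that the two limits leave unreadable from compound 2 to compound 3, cannot be read in size or direction, since both ends are limits.

The step in question leads to compound 4, `COc1ccc(CNc2nc3cc(N)cc(N)c3nc2-c2ccccc2)cc1`. It differs from compound 2 by hydrogen in place of methoxy on an aromatic carbon. Among the compounds with values here, no measured step bears readably on this change, and so no size or direction can be expected from the data beyond a guess that compound 4 will again fall under the limit. Compound 4 is estimated at 30000 nM, within 3000 nM to 100000 nM. The step from compound 2 to compound 4 is accordingly expected as a step that the limit leaves unreadable from compound 2 to compound 4, with the caveat that the starting point is itself only a limit.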

Compound 4, concentration lethal to 50% of the cells: 74100 nM
Compound 4: the middle estimate sits 2.5-fold (0.39 log units) below what was measured, within the range that was stated.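

No new step can be read in this assay: compound 4 now has a measured value, but compound 2 has only a limit, so the change from compound 2 to compound 4 cannot be sized or given a direction. The compounds shown leave open whether 4-methoxyphenyl in place of 3,4-dimethoxyphenyl alters toxicity at all.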